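Dechlorination of the sulfonyl aryl ring: compound 2 to compound 4

The compounds below may be only part of what the source reports. "The series", "measured", "known", "first", "only" and "open" are said of these compounds alone.

Measured compounds in a functional assay on MDA-MB-231 cells (Homo sapiens) for antiproliferative activity, read by MTT assay, with a stated time of 96 h; on this read-out lower numbers stand for stronger inhibition and higher numbers for weaker inhibition:
compound 1, `CC(C)=CCC/C(C)=C/CC/C(C)=C/CC[C@]1(C)CCc2cc(OC(=O)NS(=O)(=O)c3ccc(Cl)cc3)cc(C)c2O1`, gives > 10000 nM, a limit of the assay.
compound 2, `CC(C)=CCC/C(C)=C/CC/C(C)=C/CC[C@]1(C)CCc2cc(OC(=O)NS(=O)(=O)c3ccc(Cl)cc3)c(C)c(C)c2O1`, gives > 10000 nM, a limit of the assay.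
compound 3, `CC(C)=CCC/C(C)=C/CC/C(C)=C/CC[C@]1(C)CCc2c(C)c(OC(=O)NC(=O)Oc3ccccc3)c(C)c(C)c2O1`, gives > 10000 nM, a limit of the assay.

For the measured compounds named here, every value so far sits at the limit of > 10000 nM in this assay, at which 3 of the 3 values shown sit; no number has been recorded. Compound 2 therefore stands at the limit of this assay, and the two further values known are limits as well. Going by the values given here, the one step between compounds differing in a single place, a step that the two limits leave unreadable from compound 1 to compound 2, cannot be read, since both ends are limits; methyl in place of hydrogen on an aromatic carbon produced nothing the read-out could register. Compound 3 adds nothing beyond another limit.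

Compound 4, `CC(C)=CCC/C(C)=C/CC/C(C)=C/CC[C@]1(C)CCc2cc(OC(=O)NS(=O)(=O)c3ccccc3)c(C)c(C)c2O1`, awaits measurement in this assay. It differs from compound 2 by hydrogen in place of chloro on an aromatic carbon. Among the compounds with values here, no measured step bears on this change: the only step in hand, a step that the two limits leave unreadable from compound 1 to compound 2, is unreadable and concerns another position. Nothing in the series shows any change pulling a value under the limit. The step that the limit leaves unreadable from compound 2 to compound 4 is therefore the expected outcome, with no direction beyond the scatter anticipated. For compound 4 the estimate in this assay is 15000 nM, expected between 5000 nM and 50000 nM, most likely reported again only as a limit.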

Compound 4, half-maximal inhibitory concentration: > 10000 nM
Compound 4 ended at the assay's limit (the forecaster's own chance of this, stated with the estimate: 85%); the middle value lies beyond the limit too.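

The step between compound 2 and compound 4 cannot be read, since in this assay both compounds give a limit of the assay and not a number: the limit of > 10000 nM in this assay, at which 4 of the 4 values shown sit.

The compounds shown leave open whether chloro or hydrogen on that aromatic carbon, or any other difference among them, shifts the read-out at all, as none gives a value under the limit.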